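Isopropyl in place of 2-chlorophenyl: an expected cytotoxicity

The source may report more compounds than this note shows. Statements on the series, on what has been measured and on what is new or still open speak of the compounds shown alone.

Measured compounds in a functional assay on MCF7 cells (Homo sapiens) for cytotoxicity, read by MTT assay, with a stated time of 72 h; a higher number here means a weaker inhibitor, a lower number a stronger inhibitor:
compound 1, `Clc1ccccc1-c1nnc2nnc(N3CCCC3)nn12`, gives 29600 nM
compound 3, `Fc1ccc(-c2nnc3nnc(N4CCCCC4)nn23)cc1`, gives 41400 nM
compound 2, `Fc1ccc(-c2nnc3nnc(N4CCCC4)n3n2)cc1`, reaches only the limit of > 100000 nM

Going by the values given here, only two of the three compounds give a number. Compound 1 gives one of them, and compound 3 gives a number that sits within the usual scatter of it, so the two cannot be told apart on this evidence. For compound 2 the value is a limit of the assay and not a number, the one described by the limit of > 100000 nM in this assay, at which 1 of the 3 values shown sits.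

The untested compound 4, `CC(C)c1nnc2nnc(N3CCCC3)nn12`, differs from compound 1 in one place: isopropyl in place of 2-chlorophenyl on an aromatic carbon. Among the compounds with values here, no pair of measured compounds differs in this way, so the size of this step has no measured counterpart. The three measured compounds all carry an aromatic ring at this position, and none tells how a small branched alkyl group behaves there.

Given only weak inhibition across the measured set, compound 4 is expected to stay in the same weak range or become somewhat weaker, with 60000 nM as the central estimate and a range from 25000 nM to 150000 nM. That expectation corresponds to an estimated change of a 2.0-fold higher number from compound 1 to compound 4 (0.31 log units; beyond the scatter), possibly a little beyond the scatter, with a real chance that only a limit is reported.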

Compound 4, half-maximal inhibitory concentration: 46800 nM
Beside the measured number, compound 4's estimate is 1.3-fold (0.11 log units) above it, within the range that was stated.
By their numbers in this assay, from the lowest: compounds 1, 3 and 4 (each within the scatter of the next). At a limit, above all of these: compound 2.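

Replacing 2-chlorophenyl with isopropyl on this aromatic carbon in this assay gives a 1.6-fold higher number from compound 1 to compound 4 (0.20 log units; within the scatter), so the two compounds cannot be told apart. Going by these compounds alone, this is the first information on a group without a ring at this position: a group of 7 heavy atoms with an aromatic ring gives way to one of 3 heavy atoms with no ring, and the cytotoxicity, weak in both compounds, shows no measurable difference. Nothing measured here explains this outcome.

With isopropyl as the only alkyl group shown at this position, it remains open whether a longer chain such as n-hexyl, or a chain ending in an amine or a carboxylic acid, would give a number beyond the scatter of compound 1. Within the data shown here, it also remains open whether the same replacement would give a similar result on a different amine ring, such as the one carried by compound 3, or whether any group at this position can reach strong inhibition in these cells.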